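Chloro for methyl on the aryl of a pyrazole diester

The compounds below may be only part of what the source reports. "The series", "measured", "known", "first", "only" and "open" are said of these compounds alone.

Measured so far in a functional assay on HeLa cells (Homo sapiens) for cytotoxicity, read by MTT assay, with a stated time of 48 h; a higher number here means a weaker inhibitor, a lower number a stronger inhibitor:
Compound 1 `CCOC(=O)c1c(-c2c(Cl)c3cc(C)ccc3oc2=O)nn(-c2cccc(C)c2)c1C(=O)OCC` gives 115000 nM.
Compound 2 `CCOC(=O)c1c(-c2c(Cl)c3cc(C)ccc3oc2=O)nn(-c2cccc(Cl)c2)c1C(=O)OCC` gives 125000 nM.
Compound 3 `COC(=O)c1c(-c2cc3ccccc3oc2=O)nn(-c2cccc(C)c2)c1C(=O)OC` gives 45000 nM.

Within the data shown here, the one change made between compound 1 and compound 2 is chloro in place of methyl on an aromatic carbon. Its effect, a 1.1-fold higher number from compound 1 to compound 2 (0.04 log units; within the scatter), is a step too small to count as a real difference between the two.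

Compound 3 carries a different core, and the difference between the two cores is not broken down here. Within the three measured compounds, compound 3 gives the lowest number; its nearest neighbour is compound 1, and both steps from compound 3 to the others lie beyond the scatter.

Compound 4 `COC(=O)c1c(-c2cc3ccccc3oc2=O)nn(-c2cccc(Cl)c2)c1C(=O)OC` is not yet measured. It differs from compound 3 by chloro in place of methyl on an aromatic carbon, the same change that was made from compound 1 to compound 2, at the same kind of place.

The expected step in this assay is a 1.1-fold higher number from compound 3 to compound 4 (0.03 log units; within the scatter), small, because the earlier step of a 1.1-fold higher number from compound 1 to compound 2 (0.04 log units; within the scatter) was within the scatter. Compound 4 is therefore estimated at 48000 nM, with a range from 25000 nM to 95000 nM.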

Compound 4, half-maximal inhibitory concentration: 76000 nM
Compound 4: the middle estimate sits 1.6-fold (0.20 log units) below what was measured; the measured number falls inside the stated range.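

In this assay the swap of 3-methylphenyl for 3-chlorophenyl on the second core gives a 1.7-fold higher number from compound 3 to compound 4 (0.23 log units; within the scatter) and so, as on the first core, stays too small to count as a real difference. Set side by side, the two steps do not differ from each other: the same change on two cores in this assay, a 1.1-fold higher number (0.04 log units; within the scatter) from compound 1 to compound 2 and a 1.7-fold higher number (0.23 log units; within the scatter) from compound 3 to compound 4, 1.6-fold (0.19 log units) apart, within the scatter of two such steps. The change therefore carries across these two cores as a step that cannot be told from the scatter, but two pairs show nothing about how it would behave on any other core in the series, and they do not prove that chloro and methyl are truly equivalent here.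

The compounds shown leave open how this position would respond to a group of a different kind, such as an amine or a carboxylic acid in place of the chloro or methyl. They also leave open whether the two cores would still read alike with such a group, which the methyl and chloro pairs cannot tell.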